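From compound 3 to compound 4: esters at the limit

The compounds below may be only part of what the source reports. "The series", "measured", "known", "first", "only" and "open" are said of these compounds alone.

Compound 1, `CC/C=C/CC(=O)OCC1COCCOCCOCCOCCOCCO1`. In a functional assay on HeLa cells (Homo sapiens) for inhibition, read by sulforhodamine B assay, with a stated time of 48 h (a lower number here means a stronger inhibitor of growth, a higher number a weaker inhibitor of growth), compound 1 gives > 100000 nM, which is a limit of the assay and not a number.
Compound 2, `O=C(CCCCOc1ccccc1)OCC1COCCOCCOCCOCCOCCO1`. In this assay compound 2 gives > 100000 nM, again a limit of the assay.
Compound 3, `CC(=O)OCC1COCCOCCOCCOCCOCCO1`. In this assay compound 3 gives > 100000 nM, also a limit of the assay.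

Compound 3 therefore stands nowhere in particular on a scale: its value is a limit, and the two other values shown are limits too (the limit of > 100000 nM in this assay, at which 3 of the 3 values shown sit). The three compounds share the same core and differ only in the group on the saturated chain carbon bound to the carbonyl carbon, yet none of the steps between them can be read: a step that the two limits leave unreadable from compound 1 to compound 2, a step that the two limits leave unreadable from compound 1 to compound 3 and a step that the two limits leave unreadable from compound 2 to compound 3.

Compound 4, `O=C(CCCc1cc2ccccc2[nH]1)OCC1COCCOCCOCCOCCOCCO1`, differs from compound 3 by 2-(1H-indol-2-yl)ethyl in place of hydrogen on a saturated chain carbon bound to a carbonyl carbon. Among the measured compounds shown here, no measured step bears on this change in a readable way, since every step so far joins two limits. With nothing to point to a change, compound 4 is expected to sit where compound 3 sits, so the expected step is a step that the limit leaves unreadable from compound 3 to compound 4. Compound 4 is thus estimated at 150000 nM in this assay, within a range of 30000 nM to 500000 nM, most likely again reported only as a limit.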

Compound 4, concentration for 50% growth inhibition: > 100000 nM
Compound 4: no number, only a limit; the forecaster's own chance of this, stated with the estimate: 80%; the middle value lies beyond the limit too.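

In this assay compound 4 gives > 100000 nM, which is a limit of the assay and not a number. No step from compound 1, compound 2 or compound 3 to compound 4 can be read: the limit of > 100000 nM in this assay, at which 4 of the 4 values shown sit.

The compounds shown leave open whether any group at this place on the shared core gives a readable growth inhibition, and how these four compounds would rank.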